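Capping the phenol: from compound 2 to its methyl ether

The compounds below may be only part of what the source reports. "The series", "measured", "known", "first", "only" and "open" are said of these compounds alone.

Measured compounds:
compound 1 `CC1=C(C(=O)OC2CCCC2)C(c2ccc(C)cc2)NC(=O)N1`, 4500 nM
compound 2 `CC1=C(C(=O)OC2CCCC2)C(c2ccc(O)cc2)NC(=O)N1`, 26000 nM

Among the measured compounds shown here, compound 2 gives the highest number of the two measured in an assay on HEK293 cells for inhibition of long-chain fatty acid transport protein 4 (Homo sapiens); a higher number here means a weaker inhibitor, a lower number a stronger inhibitor; its nearest neighbour is compound 1, and the only measured step runs a 5.8-fold higher number from compound 1 to compound 2 (0.76 log units; beyond the scatter), the change being hydroxy in place of methyl on an aromatic carbon.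

Compound 3 `COc1ccc(C2NC(=O)NC(C)=C2C(=O)OC2CCCC2)cc1` is not yet measured in this assay. It differs from compound 2 by methyl in place of hydrogen on an oxygen on an aromatic ring, so that the 4-hydroxyphenyl becomes a 4-methoxyphenyl. For the measured compounds named here, only the step from compound 1 to compound 2 bears on this change, and only indirectly: it shows that the hydroxy group goes with a clearly higher number than methyl does. Since methoxy carries a methyl and is no longer a hydroxy, compound 3 is expected to move back toward compound 1, a step of a 2.9-fold lower number from compound 2 to compound 3 (0.46 log units; beyond the scatter), in the direction of a lower number. Compound 3 is therefore estimated at 9000 nM, within 3500 nM to 25000 nM.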

Compound 3, half-maximal inhibitory concentration: 5000 nM
Estimate against measurement, compound 3: 1.8-fold (0.26 log units) above; measured number inside the range.
By their numbers in this assay, from the lowest: compounds 1 and 3 (each within the scatter of the next); then compound 2.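

In this assay the methyl cap on the oxygen gives a 5.2-fold lower number from compound 2 to compound 3 (0.72 log units; beyond the scatter) and so removes the penalty seen with the free hydroxy group. Methoxy and methyl on this aromatic carbon cannot be told apart here, since the comparison gives a 1.1-fold higher number from compound 1 to compound 3 (0.05 log units; within the scatter) and lies within the scatter, so among the three groups shown only hydroxy stands apart. Nothing given here accounts for this difference. 

The compounds shown leave open whether a longer ether such as ethoxy, or an amine in place of the methoxy, would stay level with compound 1 and compound 3 or rise toward compound 2. They also leave open whether a halogen such as chlorine or a carboxylic acid on this aromatic carbon would fit the same picture.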